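The source may hold more compounds than are shown below. What is called first, only, known or untested is meant among the compounds shown, and "the series" means these compounds.

Compound 1 `ClCc1cccc(Cn2cnc3ncnc(Cl)c32)c1` is one of three closely related substances tested in a functional assay on SNB-75 cells (Homo sapiens) for cytotoxicity, read by sulforhodamine B assay, with a stated time of 48 h; a lower number here means a stronger inhibitor of growth, a higher number a weaker inhibitor of growth. In this assay compound 1 gives 1860 nM. Compound 2 `ClCc1ccc(Cn2cnc3nc(Cl)nc(Cl)c32)cc1` gives 2080 nM, and compound 3 `ClCc1cccc(Cn2cnc3c(Cl)nc(Cl)nc32)c1` gives 2040 nM; all three numbers sit within the usual scatter of one another, so none can be called stronger or weaker. Compound 4 `ClCc1cccc(Cn2cnc3nc(Cl)nc(Cl)c32)c1` has not yet been measured. It differs from compound 1 by chloro in place of hydrogen on an aromatic carbon, the new chloro sitting between two ring nitrogen atoms of the shared core. For the measured compounds named here, no single-change step between measured compounds exists to guide the expectation. Compound 2 carries two chlorines and gives 2080 nM, and compound 3, also carrying two chlorines, gives 2040 nM; both numbers sit within the scatter of compound 1. The step of a 1.0-fold higher number from compound 1 to compound 4 (0.01 log units; within the scatter) is therefore expected to be none beyond the scatter. Compound 4 is estimated at 1900 nM, with a range from 900 nM to 4000 nM.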

Compound 4, concentration for 50% growth inhibition: 1090 nM
Estimate against measurement, compound 4: 1.7-fold (0.24 log units) above; low and high end bracket the measured number.
By their numbers in this assay, from the lowest: compounds 4, 1, 3 and 2 (each within the scatter of the next).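

For the compounds shown here, this is the first single change that can be read at this position, on an aromatic carbon between two ring nitrogen atoms. In this assay, chloro in place of hydrogen gives a 1.7-fold lower number from compound 1 to compound 4 (0.23 log units; within the scatter), so the chloro can be neither credited with stronger growth inhibition nor blamed for weaker. No measurement shown here bears on what lies behind this result. From the compounds shown here alone, whether a different group at this position, such as an amine or a methoxy group, would give a step beyond the scatter remains open.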